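The source may report more compounds than this note shows. Statements on the series, on what has been measured and on what is new or still open speak of the compounds shown alone.

The three measured compounds share one core, varied at a single aromatic carbon. Compound 1 `COC(=O)/C=C/c1cccc(N(Cc2ccc(-c3cccc(Cl)c3)cc2)C(=O)C2CCCCC2)c1` gives 94 nM in an assay on isolated protein with Bile acid receptor (Homo sapiens) as the target; on this read-out lower numbers stand for an effect already at smaller amounts and higher numbers for an effect only at larger amounts of compound. Compound 3 `COC/C=C/c1ccc(CN(C(=O)C2CCCCC2)c2cccc(/C=C/C(=O)OC)c2)cc1` gives 233 nM in this assay, the highest of the two numbers obtained; the nearest number lies lower, as a 2.5-fold higher number from compound 1 to compound 3 (0.39 log units; beyond the scatter) shows. Compound 2 `COC(=O)/C=C/c1cccc(N(Cc2ccc(/C=C/C(=O)OCc3ccccc3)cc2)C(=O)C2CCCCC2)c1` reaches only a limit of the assay, > 1000 nM in this assay (the limit of > 1000 nM in this assay, at which 1 of the 3 values shown sits). Compound 4 `COC(=O)/C=C/c1cccc(N(Cc2ccc(-c3ccc(OC(F)(F)F)cc3)cc2)C(=O)C2CCCCC2)c1` is not yet measured and differs from compound 3 in one place: 4-(trifluoromethoxy)phenyl in place of 3-methoxyprop-1-en-1-yl on an aromatic carbon. The 3-methoxyprop-1-en-1-yl chain leaves and a six-membered aromatic ring of carbon only enters. The step bearing most on this is a 2.5-fold higher number from compound 1 to compound 3 (0.39 log units; beyond the scatter), where 3-chlorophenyl gave way to a chain with a modest rise; an at least 10-fold higher number from compound 1 to compound 2 (1.02 log units; beyond the scatter) likewise shows the 3-chlorophenyl of compound 1 ahead of a chain. Returning to a phenyl ring in compound 4 is therefore expected to bring a modest fall, a 2.3-fold lower number from compound 3 to compound 4 (0.37 log units; beyond the scatter), in this assay. Compound 4 is estimated at 100 nM, within 40 nM to 300 nM.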

Compound 4, half-maximal effective concentration: 264 nM
Beside the measured number, compound 4's estimate is 2.6-fold (0.42 log units) below it, and the stated range covers the measured number.
By their numbers in this assay, from the lowest: compound 1; then compounds 3 and 4 (each within the scatter of the next). At a limit, above all of these: compound 2.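

Putting an aromatic ring back at this position does not by itself recover the lower number: exchanging the 3-methoxyprop-1-en-1-yl chain for 4-(trifluoromethoxy)phenyl gives a 1.1-fold higher number from compound 3 to compound 4 (0.05 log units; within the scatter), so this ring and this chain cannot be told apart here, and compounds 3 and 4 go against any rule that rings beat chains. Rings also differ among themselves, as exchanging 3-chlorophenyl for 4-(trifluoromethoxy)phenyl gives a 2.8-fold higher number from compound 1 to compound 4 (0.45 log units; beyond the scatter). Only the 2-(benzyloxycarbonyl)ethenyl chain stays clearly apart from this ring, with an at least 3.7-fold lower number from compound 2 to compound 4 (0.57 log units; beyond the scatter), a step read against a limit and not a number: the limit of > 1000 nM in this assay, at which 1 of the 4 values shown sits.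

As far as these compounds go, whether an unsubstituted phenyl, a 4-chlorophenyl or a 3-(trifluoromethoxy)phenyl ring would lie nearer compound 1 or compound 4 remains open. So does how a chain ending in an amine or a carboxylic acid would fare at this position.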